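A few compounds are considered here, and "the series" means these few. Any claim that something is new, unique, unknown or untested is made for them only; others in the source may bear on it.

Compound 1 `COc1cc(-c2cc(/C=C/C(=O)c3ccc(N)cc3)[nH]n2)cc(OC)c1OC`: -86%; compound 2 `COc1cc(-c2cc(/C=C/C(=O)c3ccc(Cl)c(Cl)c3)[nH]n2)cc(OC)c1OC`: -71%; compound 3 `COc1ccc(C(=O)/C=C/c2cc(-c3cc(OC)c(OC)c(OC)c3)n[nH]2)cc1`: -93%.

All three were measured in a functional assay on RXF 393 cells (Homo sapiens) for cytotoxicity, read by sulforhodamine B assay, with a stated time of 48 h, tested at 100 uM; on this read-out lower numbers stand for a stronger effect and higher numbers for a weaker effect at the one concentration tested. Compound 3 has the lowest of the three numbers, but compound 1 lies within the scatter of it, so only compound 2 stands clearly apart. Compound 4 `COc1cc(-c2cc(/C=C/C(=O)c3ccc(F)c(F)c3)[nH]n2)cc(OC)c1OC` is not yet measured; it differs from compound 3 by 3,4-difluorophenyl in place of 4-methoxyphenyl on a carbonyl carbon. Within the data shown here, two measured steps bear on this change: a number 22 percentage points lower from compound 2 to compound 3 (beyond the scatter) and a number 15 percentage points higher from compound 1 to compound 2 (beyond the scatter). In both, the 3,4-dichlorophenyl ring went with the higher number than the 4-methoxyphenyl or 4-aminophenyl ring, so a modest upward step is expected here, resting on only these two steps. For compound 4 a value of -78% is estimated, between -92% and -62%. This expectation corresponds to a number 15 percentage points higher from compound 3 to compound 4 (beyond the scatter).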

Compound 4, a percentage reported as activity, at one concentration (the size of the read-out at that concentration, not a potency): -61%
Estimate against measurement, compound 4: 17 percentage points below, outside the stated range (above it).
By their numbers in this assay, from the lowest: compounds 3 and 1 (each within the scatter of the next); then compounds 2 and 4 (each within the scatter of the next).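

Putting 3,4-difluorophenyl on the carbonyl carbon in place of 4-methoxyphenyl gives the largest step yet in this assay (a number 32 percentage points higher from compound 3 to compound 4 (beyond the scatter)), and replacing 4-aminophenyl also gives a step beyond the scatter (a number 25 percentage points higher from compound 1 to compound 4 (beyond the scatter)). Exchanging one halogenated ring for the other stays within the scatter (a number 10 percentage points higher from compound 2 to compound 4 (within the scatter)), so among these four compounds, with none going against it, the two halogenated rings group together, apart from the methoxy and amino rings. Nothing available explains this split.

On these data alone, whether a ring with one fluorine, such as 4-fluorophenyl, would group with them stays open. So does the behaviour of a ring carrying a carboxylic acid.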